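The source may hold more compounds than are shown below. What is called first, only, known or untested is meant among the compounds shown, and "the series" means these compounds.

The measured compounds and their values in an assay on membranes from HeLa cells for displacement of a labelled ligand from adenosine receptor A3 (Homo sapiens), read by scintillation counting, with a stated time of 180 min, tested at 1 uM (a higher number here means more inhibition at the concentration tested (going by the name of the read-out), a lower number less inhibition), are:

Compound 1, `COC(=O)C1=C(C)NC(=O)NC1c1ccoc1`: 2%
Compound 2, `CCCOC(=O)C1=C(C)NC(=O)NC1c1cccs1`: 32%
Compound 3, `COC(=O)C1=C(C)NC(=S)NC1c1ccoc1`: 3%

Compound 3, the structure `COC(=O)C1=C(C)NC(=S)NC1c1ccoc1`, gives 3% in this assay. That number sits within the scatter of the value of compound 1, 2%, so the two cannot be told apart on these data, while the value of compound 2, 32%, lies above it by more than the scatter. Compound 2 differs from compound 3 in more than one place, so no single step is shown between any two of the measured compounds.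

The next compound, compound 4, is `CC1=C(C(=O)OC(C)(C)C)C(c2ccoc2)NC(=S)N1`. It differs from compound 3 in one place: tert-butyl in place of methyl on an oxygen next to a carbonyl group. There is no measured pair in this series that makes this same change, so its effect cannot be read from the numbers shown. For the measured compounds named here, with the ester alkyl group being the only thing that changes and the rest of the structure held the same, the expectation is a small step, either way, that stays within the scatter. Compound 4 is thus expected to give about 8% in this assay, in a range from 0% to 25%. This estimate means a step of a number 5 percentage points higher from compound 3 to compound 4 (within the scatter) is expected.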

Compound 4, a percentage reported as inhibition, at one concentration (the size of the read-out at that concentration, not a potency): 19%
For compound 4 the middle estimate is 11 percentage points below the measured one; low and high end bracket the measured number.
By their numbers in this assay, from the lowest: compounds 1 and 3 (each within the scatter of the next); then compound 4; then compound 2.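

In this assay, the group on this ester oxygen proves able to change the read-out: tert-butyl in place of methyl on an oxygen next to a carbonyl group gives a number 16 percentage points higher from compound 3 to compound 4 (beyond the scatter). For the compounds shown here, this is the first change in one place that can be read, so the effect can be assigned to this swap alone, with the rest of the structure held the same, although it remains a modest step seen in a single pair and not a trend. Nothing measured here accounts for the step, so the reason for it stays unknown.

The compounds shown leave open whether the rise needs tert-butyl itself or would also appear with an ethyl or isopropyl group, or with a longer chain such as n-butyl, on the same oxygen. Also open, as far as these compounds go, are whether tert-butyl would give a similar step on the core of compound 1, and how a carboxylic acid or an amide would compare with the ester at this place.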